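Thiazolidinedione amides: limits only, fourth compound pending

This account rests on a few compounds, and the source may have more. Where it says the series, first, only, none or still open, it means among the compounds named here.

Measured so far, with the read-out a functional assay on PC-3 cells (Homo sapiens) for inhibition, read by MTT assay, with a stated time of 48 h; on this read-out lower numbers stand for stronger inhibition and higher numbers for weaker inhibition:

compound 1, `CCn1c(/C=C2\SC(=O)N(CC(=O)N3CCCCC3)C2=O)nc2ccccc21`, gives > 50000 nM, which is a limit of the assay and not a number.
compound 2, `CCn1c(/C=C2\SC(=O)N(CC(=O)N3CCCC3)C2=O)nc2ccccc21`, gives > 50000 nM, likewise a limit.
compound 3, `CC(C)n1c(/C=C2\SC(=O)N(CC(=O)N3CCCC3)C2=O)nc2ccccc21`, gives > 50000 nM, likewise a limit.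

All three sit at the same limit, stated as the limit of > 50000 nM in this assay, at which 3 of the 3 values shown sit. Within this assay compound 2 and compound 1 differ by piperidin-1-yl in place of pyrrolidin-1-yl on a carbonyl carbon, and the resulting step that the two limits leave unreadable from compound 2 to compound 1 cannot be sized, since both ends are limits. Compound 2 and compound 3 differ in their cores by methyl in place of hydrogen on a saturated chain carbon bound to an aromatic nitrogen and a saturated chain carbon, and again the step that the two limits leave unreadable from compound 2 to compound 3 is not readable.

Compound 4, `CC(C)n1c(/C=C2\SC(=O)N(CC(=O)N3CCCCC3)C2=O)nc2ccccc21`, is not yet measured. It differs from compound 3 by piperidin-1-yl in place of pyrrolidin-1-yl on a carbonyl carbon, which is the same change that was made from compound 2 to compound 1, at the same place. The two pairs differ only in their cores, as described above for compound 2 and compound 3.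

The matching change from compound 2 to compound 1 left both values at the limit of > 50000 nM in this assay, at which 3 of the 3 values shown sit, and compound 3 itself sits at that limit. On that basis compound 4 is expected to show the step that the limit leaves unreadable from compound 3 to compound 4 in this assay. Compound 4 is therefore expected to give about 80000 nM, most likely again reported only as a limit, with a plausible range from 30000 nM to 300000 nM.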

Compound 4, half-maximal inhibitory concentration: > 50000 nM
Compound 4: no number, only a limit; the forecaster's own chance of this, stated with the estimate: 90%; the middle value does not contradict the limit.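

In this assay compound 4 gives > 50000 nM, a limit of the assay and not a number. The steps from compound 3 to compound 4 and from compound 1 to compound 4 cannot be read, and the series stands at one value: the limit of > 50000 nM in this assay, at which 4 of the 4 values shown sit.

The compounds shown leave open whether piperidin-1-yl in place of pyrrolidin-1-yl, or the added methyl, changes inhibition at all.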